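The source may hold more compounds than are shown below. What is called first, only, known or untested is meant among the compounds shown, and "the series" means these compounds.

Compound 2 `NC(=O)c1ccc2[nH]c(-c3ccc(OCCCN4CCCCC4)cc3)nc2c1` is the reference point. In a physicochemical assay for solubility, with a stated time of 3 days, at pH 2 (on this read-out higher numbers stand for higher solubility and lower numbers for lower solubility), compound 2 gives > 400000 nM, and this is a limit of the assay rather than a number. Compound 1 `NC(=O)c1ccc2[nH]c(-c3ccc(OCCCO)cc3)nc2c1`, which carries the hydroxy group at the end of the same chain, gives 185000 nM in this assay. Among the measured compounds shown here, the step of an at least 2.1-fold higher number from compound 1 to compound 2 (0.33 log units; beyond the scatter) is the only measured step in the set, and its upper end is set by the limit of > 400000 nM in this assay, at which 1 of the 3 values shown sits. Compound 3 `NC(=O)c1ccc2[nH]c(-c3ccc(OC4CCNCC4)cc3)nc2c1` has "not determined" (no result reported) in this assay, so it adds nothing to the comparison.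

Compound 4 `NC(=O)c1ccc2[nH]c(-c3ccc(OCC4CCNCC4)cc3)nc2c1` differs from compound 2 as follows: piperidin-4-yl in place of 2-(piperidin-1-yl)ethyl on a saturated chain carbon bound to an oxygen on an aromatic ring. For the measured compounds named here, no measured step covers this change. Going by the values given here, the one step that is known runs between compound 1 and compound 2, and it bears on the end of the chain, not on the shortened linker that compound 4 carries. Compound 2 already sits at the limit, so the expected step of an at least 1.3-fold lower number from compound 2 to compound 4 (0.12 log units; that floor lies within the scatter) cannot be read from the numbers and is set near no change. Compound 4 is therefore expected to give about 300000 nM, within a range from 120000 nM to 700000 nM.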

Compound 4, solubility: > 400000 nM
Compound 4: a limit, no number; the forecaster's own chance of this, stated with the estimate: 45%; middle value at least 1.3-fold (0.12 log units) from the limit.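

Compound 4 sits at the same limit of the assay as compound 2, so in this assay a second amine-bearing group on a saturated chain carbon bound to an oxygen on an aromatic ring also reaches that limit. The change to piperidin-4-yl from the hydroxy-ended chain gives an at least 2.1-fold higher number from compound 1 to compound 4 (0.33 log units; beyond the scatter), so the rise seen earlier, an at least 2.1-fold higher number from compound 1 to compound 2 (0.33 log units; beyond the scatter), is no longer tied to 2-(piperidin-1-yl)ethyl alone. The step between compound 2 and compound 4 cannot be read, and the two cannot be placed in order: the limit of > 400000 nM in this assay, at which 2 of the 4 values shown sit.

From the compounds shown here alone, how far compound 2 and compound 4 lie past the limit remains open. So does whether an open-chain dimethylamino group or a carboxylic acid at the end of the chain would also reach it.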